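The source may report more compounds than this note shows. Statements on the series, on what has been measured and on what is new or still open speak of the compounds shown alone.

Of the compounds shown here, three of one shared core have been measured in an in vivo ADME assay on the whole organism for metabolic stability, with Canis familiaris (Canis lupus familiaris) as the target; on this read-out lower numbers stand for a shorter-lived compound and higher numbers for a longer-lived compound. Compound 1, `Nc1noc2ccc(-n3nc(C(F)(F)F)c4c3C(=O)N(c3ccc(-c5ccccc5CN5CCCC5)cc3)CC4)cc12`, gives 5.3 h. Compound 2, `Nc1noc2ccc(-n3nc(C(F)(F)F)c4c3C(=O)N(c3ccc(-c5ccccc5CN5CC[C@@H](O)C5)cc3F)CC4)cc12`, gives 5.9 h. Compound 3, `CNCc1ccccc1-c1ccc(N2CCc3c(C(F)(F)F)nn(-c4ccc5onc(N)c5c4)c3C2=O)cc1`, gives 7.4 h. Compound 2 therefore holds the second highest of the three numbers, yet it sits within the usual scatter of both compound 1 and compound 3, so no order can be read among them.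

Compound 4, `CN(C)Cc1ccccc1-c1ccc(N2CCc3c(C(F)(F)F)nn(-c4ccc5onc(N)c5c4)c3C2=O)c(F)c1`, has not yet been measured. It differs from compound 2 in one place: dimethylamino in place of 3-hydroxypyrrolidin-1-yl on a saturated chain carbon bound to an aromatic carbon. Among the measured compounds shown here, the one measured step that resembles this change is a 1.4-fold higher number from compound 1 to compound 3 (0.14 log units; within the scatter), where a ring on the same saturated chain carbon was exchanged for an open-chain amine and the number barely moved. For the measured compounds named here, compound 2 and compound 4 are linked by a change of the same kind, a ring for a small open-chain amine, and nothing among the measured compounds points to a shift beyond the scatter.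

Compound 4 is therefore expected to show a step of a 1.0-fold higher number from compound 2 to compound 4 (0.01 log units; within the scatter) in this assay. The half-life of compound 4 is estimated at 6 h, with a likely range from 3 h to 12 h, since compound 2 gave 5.9 h and compound 3 gave 7.4 h with little spread.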

Compound 4, half-life: 6.4 h
Beside the measured number, compound 4's estimate is 1.1-fold (0.03 log units) below it; the range from low to high includes it.
By their numbers in this assay, from the lowest: compounds 1, 2, 4 and 3 (each within the scatter of the next).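

In this assay, the step of a 1.1-fold higher number from compound 2 to compound 4 (0.04 log units; within the scatter) shows that the half-life stays within the scatter when dimethylamino replaces 3-hydroxypyrrolidin-1-yl on a saturated chain carbon bound to an aromatic carbon. The earlier step of a 1.4-fold higher number from compound 1 to compound 3 (0.14 log units; within the scatter) had already shown an open-chain amine taking the place of a ring at this position, but that ring was a plain pyrrolidin-1-yl; here the ring, its hydrogen-bond donor and its defined stereocentre all leave at once, and the reading still shows no change that can be told from scatter. So at this position, the half-life in the dog has so far tolerated both open-chain and ring amines, with or without the hydroxy group, though nothing measured here explains why.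

All the groups shown at this position are amines, so it remains open whether a group of another kind, such as a carboxylic acid, or a longer chain carrying the amine would move the half-life beyond the scatter. A larger ring amine such as morpholin-4-yl is equally untested by these compounds.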